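A Larger Group in Place of Fluoro: Compound 4

A few compounds are considered here, and "the series" means these few. Any claim that something is new, unique, unknown or untested is made for them only; others in the source may bear on it.

Of the compounds shown here, three sharing one core have been measured in an assay on HEK293 cells for displacement of a labelled ligand from 5-hydroxytryptamine receptor 6 (Homo sapiens); a lower number here means a stronger inhibitor, a higher number a weaker inhibitor. Compound 1 `O=S(=O)(c1ccccc1)N1CCOc2c(N3CCNCC3)cccc21` gives 12.6 nM. Compound 2 `O=S(=O)(c1cccc(Cl)c1)N1CCOc2c(N3CCNCC3)cccc21` gives 2 nM, and compound 3 `O=S(=O)(c1cccc(F)c1)N1CCOc2c(N3CCNCC3)cccc21` gives 10 nM. Among these three, compound 3 stands second highest; its nearest neighbour is compound 1, with a 1.3-fold lower number from compound 1 to compound 3 (0.10 log units; within the scatter), while compound 2 lies furthest, with a 5.0-fold higher number from compound 2 to compound 3 (0.70 log units; beyond the scatter). Compound 4 `CS(=O)(=O)Nc1cccc(S(=O)(=O)N2CCOc3c(N4CCNCC4)cccc32)c1` has not yet been measured. It differs from compound 3 in one place: methanesulfonamido in place of fluoro on an aromatic carbon. No measured step involves a methanesulfonamido group, so the expectation rests on what the same position has shown. The step of a 1.3-fold lower number from compound 1 to compound 3 (0.10 log units; within the scatter) shows that placing fluoro there changed little, and the step of a 6.3-fold lower number from compound 1 to compound 2 (0.80 log units; beyond the scatter) shows that chloro brought a modest gain. The position therefore accepts change, but the entering group is unlike either of those, which makes the outcome uncertain. For compound 4 an estimated step of no change at the digits printed from compound 3 to compound 4 (within the scatter) is expected, not beyond the scatter. Compound 4 is estimated at 10 nM, with a range from 3 nM to 40 nM.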

Compound 4, inhibition constant: 200 nM
Compound 4: the middle estimate sits 20-fold (1.30 log units) below what was measured, outside the stated range (above it).
By their numbers in this assay, from the lowest: compound 2; then compounds 3 and 1 (each within the scatter of the next); then compound 4.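

In this assay, among these compounds, this position proved far less tolerant than the earlier compounds suggested, since methanesulfonamido raises the number in every comparison (a 20-fold higher number from compound 3 to compound 4 (1.30 log units; beyond the scatter); a 16-fold higher number from compound 1 to compound 4 (1.20 log units; beyond the scatter); a 100-fold higher number from compound 2 to compound 4 (2.00 log units; beyond the scatter)). Fluoro and chloro had left the number unchanged or lowered it relative to hydrogen, so this is the first group shown here to weaken binding, and large steps separate it from all three earlier compounds. Methanesulfonamido differs from those smaller substituents in several ways at once, including its 5 heavy atoms, hydrogen-bond donor and hydrogen-bond acceptors, and nothing available here identifies which difference accounts for the loss.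

On these data alone, it remains open whether a simple amine or an acetamido group on the same carbon would stay near compound 2 or fall closer to compound 4. A methanesulfonyl group, which lacks the nitrogen and its hydrogen, would show whether the loss persists without them.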